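Rejoining the Thiazole and Amine of Compound 2

A few compounds are considered here, and "the series" means these few. Any claim that something is new, unique, unknown or untested is made for them only; others in the source may bear on it.

In an ADME assay on microsomes from liver (Homo sapiens) for metabolic stability (on this read-out higher numbers stand for a longer-lived compound and lower numbers for a shorter-lived compound), compound 1 (`CC(C)C(Nc1nnc[nH]1)c1ccc(-c2ccc3cccc(F)c3c2)[nH]c1=O`) gives > 3 h, which is a limit of the assay and not a number. Among the measured compounds shown here, compound 2 (`CC(C)C(Nc1nccs1)c1ccc(-c2ccc3cccc(F)c3c2)[nH]c1=O`) gives 0.17 h, the only actual number so far. For the measured compounds named here, the single measured step is an at least 17-fold lower number from compound 1 to compound 2 (1.24 log units; beyond the scatter), large and beyond the scatter.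

Compound 3 (`CC(C)C(c1cnc(N)s1)c1ccc(-c2ccc3cccc(F)c3c2)[nH]c1=O`) contains the same atoms as compound 2, joined differently: 2-amino-1,3-thiazol-5-yl in place of (1,3-thiazol-2-yl)amino on a saturated chain carbon bound to an aromatic carbon and a saturated chain carbon. The step to compound 2, an at least 17-fold lower number from compound 1 to compound 2 (1.24 log units; beyond the scatter), exchanged one ring on the amine nitrogen for another, whereas compound 3 keeps the thiazole ring, so that step is only a loose guide and compound 3 is expected to stay much closer to compound 2 than to the limit of compound 1. A modest rise within the scatter is expected, a 1.8-fold higher number from compound 2 to compound 3 (0.25 log units; within the scatter). Compound 3 is estimated at 0.3 h, with an expected range of 0.1 h to 1 h.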

Compound 3, half-life: 0.178 h
Compound 3: the middle estimate sits 1.7-fold (0.23 log units) above what was measured; the range from low to high includes it.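

Rejoining the same atoms as 2-amino-1,3-thiazol-5-yl in place of (1,3-thiazol-2-yl)amino leaves the two compounds within the scatter in this assay, with a 1.0-fold higher number from compound 2 to compound 3 (0.02 log units; within the scatter). The short half-life therefore does not depend on the thiazole being attached through the amine nitrogen, and the gap to the triazole compound remains, with an at least 16-fold lower number from compound 1 to compound 3 (1.22 log units; beyond the scatter). Among these compounds, the two carrying a thiazole sit together, and the large gap lies only against compound 1, which carries 4H-1,2,4-triazol-3-yl.

As far as these compounds go, compound 1 stands at a limit of the assay and not at a number, so the full size of both large steps stays open: the limit of > 3 h in this assay, at which 1 of the 3 values shown sits. Whether an imidazole or an oxazole on the same saturated chain carbon would stay with the thiazoles or move towards compound 1 also remains open.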